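Swapping a cyclohexyl for a pyrrole on a triazole ester

This account rests on a few compounds, and the source may have more. Where it says the series, first, only, none or still open, it means among the compounds named here.

Compound 1, `COC(=O)c1nc(-c2ccc[nH]2)n(-c2ccc(F)cc2)n1`: 9010 nM
Compound 2, `COC(=O)c1nc(C2CCCCC2)n(-c2ccc(C(F)(F)F)cc2)n1`: > 100000 nM

In a functional assay on Jurkat cells (Homo sapiens) for inhibition, read by MTT assay, with a stated time of 72 h (on this read-out higher numbers stand for weaker inhibition of growth and lower numbers for stronger inhibition of growth), compound 1 gives 9010 nM. Compound 2 gives no number in this assay but only a limit, > 100000 nM, which is the limit of > 100000 nM in this assay, at which 1 of the 2 values shown sits. Within the data shown here, compound 2 therefore stands at the weak end of the two values shown, while compound 1 is the only one with a measured number.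

Compound 3, `COC(=O)c1nc(-c2ccc[nH]2)n(-c2ccc(C(F)(F)F)cc2)n1`, has not yet been tested in this assay. It differs from compound 2 in one place: 1H-pyrrol-2-yl in place of cyclohexyl on an aromatic carbon. The resulting compound 3 carries the same 1H-pyrrol-2-yl group that compound 1 carries, differing from compound 1 only in the trifluoromethyl on the phenyl ring in place of fluorine. Among the measured compounds shown here, with no measured step between these compounds, the expectation rests on compound 1 alone, whose value of 9010 nM suggests that compound 3 should inhibit growth. The expected step from compound 2 to compound 3 is an at least 6.6-fold lower number from compound 2 to compound 3 (0.82 log units; beyond the scatter), toward stronger inhibition, beyond the scatter. Compound 3 is estimated at 15000 nM, in a range from 4000 nM to 60000 nM.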

Compound 3, concentration for 50% growth inhibition: > 100000 nM
Compound 3 ended at the assay's limit; the forecaster's own chance of this, stated with the estimate: 20%; at least 6.6-fold (0.82 log units) between middle value and limit.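

In this assay compound 3 gives > 100000 nM as a limit and not as a number. Putting trifluoromethyl in place of fluoro on the phenyl ring gives an at least 11-fold higher number from compound 1 to compound 3 (1.04 log units; beyond the scatter) in this one pair, so the 1H-pyrrol-2-yl group on the shared core does not ensure growth inhibition whatever else the molecule carries. The step between compound 2 and compound 3 cannot be read, so the swap of cyclohexyl for 1H-pyrrol-2-yl remains without a measured size: the limit of > 100000 nM in this assay, at which 2 of the 3 values shown sit.

Still open, on these data alone, is how a chlorine atom, a methoxy group or a plain hydrogen on the phenyl ring would compare with fluoro and trifluoromethyl. The compounds shown also say nothing about whether the methyl ester could give way to a carboxylic acid or an amide.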